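A few compounds are considered here, and "the series" means these few. Any claim that something is new, unique, unknown or untested is made for them only; others in the source may bear on it.

Compound 1 `CC(C)n1cc(-c2ccnc3[nH]c(C4CCN(CC(=O)N5CCCC5)CC4)cc23)ccc1=O` and compound 2 `CC(C)n1cc(-c2ccnc3[nH]c(C4CCN(CC(=O)N5CCCCC5)CC4)cc23)ccc1=O` are built on the same core and part only in the group attached to the carbonyl carbon of the side chain. In an ADME assay (Rattus norvegicus, strain Han-wistar) for metabolic stability, at a dose of 1.5 umol/kg by the intravenous route (on this read-out lower numbers stand for a shorter-lived compound and higher numbers for a longer-lived compound), compound 1 gives 1.1 h, and compound 2 gives 1.7 h. The step between them, a 1.5-fold higher number from compound 1 to compound 2 (0.19 log units; within the scatter), leaves the two values indistinguishable. For the measured compounds named here, compound 1 therefore stands lowest of the two numbers known so far, with compound 2 as its only neighbour and that neighbour within the scatter.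

Compound 3 `CC(C)n1cc(-c2ccnc3[nH]c(C4CCN(CC(=O)N(C)C)CC4)cc23)ccc1=O` is the next member of the series, and it differs from compound 1 in one place: dimethylamino in place of pyrrolidin-1-yl on a carbonyl carbon. Going by the values given here, the one measured step that bears on this change is a 1.5-fold higher number from compound 1 to compound 2 (0.19 log units; within the scatter), which also exchanged the group on the same carbonyl carbon and stayed within the scatter. On that basis the step from compound 1 to compound 3 is expected to be small, a 1.1-fold lower number from compound 1 to compound 3 (0.04 log units; within the scatter), with no direction that could be told apart from noise. Compound 3 is accordingly estimated at 1 h in this assay, with a range from 0.5 h to 2 h.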

Compound 3, half-life: 1.7 h
The estimate for compound 3 lay 1.7-fold (0.23 log units) below the measured number, and the stated range covers the measured number.
By their numbers in this assay, from the lowest: compounds 1, 2 and 3 (each within the scatter of the next).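

With this result, the group on the carbonyl carbon has been varied from a ring to no ring, and in this assay the change still has no readable effect: dimethylamino in place of pyrrolidin-1-yl gives a 1.5-fold higher number from compound 1 to compound 3 (0.19 log units; within the scatter), and dimethylamino in place of piperidin-1-yl gives no change at the digits printed from compound 2 to compound 3 (within the scatter). For the compounds shown here, the earlier pair compared only two ring-bearing groups, whereas compound 3 shows that, across these three compounds, the ring itself is not needed for a half-life within the scatter of the other two. All three compounds therefore form one group on this read-out, and no order among them can be claimed. Nothing available explains why these amides cannot be told apart.

The compounds shown leave open whether this tolerance extends to groups of a different kind on the carbonyl carbon, such as morpholin-4-yl with its ring oxygen or a simple amino group carrying hydrogens on the nitrogen. They also leave open what a carboxylic acid in place of the amide, or a longer chain leading to the carbonyl carbon, would do to the half-life.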